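Swapping piperidinyl for morpholinyl on a thiocarbonyl carbon

The source may report more compounds than this note shows. Statements on the series, on what has been measured and on what is new or still open speak of the compounds shown alone.

Measured so far in a functional assay on MCF7 cells (Homo sapiens) for antiproliferative activity, read by MTT assay, with a stated time of 72 h; on this read-out higher numbers stand for weaker inhibition and lower numbers for stronger inhibition:
compound 1 `COc1ccc2occ(CSC(=S)N3CCOCC3)c(=O)c2c1` gives 11800 nM
compound 2 `COc1ccc2occ(CSC(=S)N3CCCCC3)c(=O)c2c1` gives > 40000 nM, which is a limit of the assay and not a number
compound 3 `CCOC(=O)c1cc(=O)c2cc(CSC(=S)N3CCCCC3)ccc2o1` gives 21900 nM

Compound 1 and compound 2 share a core and differ in one place only: morpholin-4-yl in place of piperidin-1-yl on a thiocarbonyl carbon. This change made an at least 3.3-fold lower number from compound 2 to compound 1 (0.53 log units; beyond the scatter).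

Compound 3 carries a different core, and the difference between the two cores is not broken down here. Compound 3 stands highest of the two numbers that were actually read, though against compound 1 the gap is within the scatter. Compound 4 `CCOC(=O)c1cc(=O)c2cc(CSC(=S)N3CCOCC3)ccc2o1` is not yet measured. It relates to compound 3 as compound 1 relates to compound 2: morpholin-4-yl in place of piperidin-1-yl on a thiocarbonyl carbon. The place line reads the same for both pairs, so this is the same change on a different core.

The step from compound 3 to compound 4 in this assay is expected to run in the same direction, giving compound 4 an estimated 2.6-fold lower number from compound 3 to compound 4 (0.41 log units; beyond the scatter), because the one earlier occurrence of this change gave an at least 3.3-fold lower number from compound 2 to compound 1 (0.53 log units; beyond the scatter). Compound 4 is therefore expected to give about 8500 nM, estimated to fall between 3000 nM and 25000 nM.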

Compound 4, half-maximal inhibitory concentration: > 25000 nM
Compound 4: no number, only a limit; the forecaster's own chance of this, stated with the estimate: 5%; at least 2.9-fold (0.46 log units) between middle value and limit.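

In this assay compound 4 gives > 25000 nM, which is a limit of the assay and not a number. The drop in number that came with morpholin-4-yl in place of piperidin-1-yl on the core of compound 1 did not carry over to the core of compound 3, and the two steps differ: the same change on two cores in this assay, an at least 3.3-fold lower number (0.53 log units; beyond the scatter) from compound 2 to compound 1 and an at least 1.1-fold higher number (0.05 log units; that floor lies within the scatter) from compound 3 to compound 4, at least 3.8-fold (0.58 log units) apart, beyond the scatter of two such steps. This does not show that the change harms activity on the core of compound 3, as the step can be read only as an at least 1.1-fold higher number from compound 3 to compound 4 (0.05 log units; that floor lies within the scatter), and with one pair on each core and a limit in both pairs, the true size of neither step is known.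

The compounds shown leave open how each core would respond to other groups on the thiocarbonyl carbon, such as piperazin-1-yl or an open-chain diethylamino group. They also leave open whether a carboxylic acid in place of the ethyl ester would alter the result on the core of compound 3.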